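Swapping the aryl group on a thromboxane synthase inhibitor

A few compounds are considered here, and "the series" means these few. Any claim that something is new, unique, unknown or untested is made for them only; others in the source may bear on it.

compound 1 `CSc1ccc(OC(C)(C)C2OCC(C/C=C\CCC(=O)O)C(c3cccnc3)O2)c([N+](=O)[O-])c1`: 22 nM
compound 2 `CC(C)(C)c1ccc(OC(C)(C)C2OCC(C/C=C\CCC(=O)O)C(c3cccnc3)O2)cc1`: 280 nM
compound 3 `CC(C)(Oc1ccccc1Br)C1OCC(C/C=C\CCC(=O)O)C(c2cccnc2)O1`: 29 nM

In an assay for inhibition of Thromboxane-A synthase (Homo sapiens), using microsomes (a higher number here means a weaker inhibitor, a lower number a stronger inhibitor), compound 3 stands second of the three numbers; one of the steps leading to it lies within the scatter (a 1.3-fold higher number from compound 1 to compound 3 (0.12 log units; within the scatter)) and the other beyond it (a 9.7-fold lower number from compound 2 to compound 3 (0.98 log units; beyond the scatter)). Compound 4 `CC(C)(Oc1ccc(F)cc1[N+](=O)[O-])C1OCC(C/C=C\CCC(=O)O)C(c2cccnc2)O1` differs from compound 3 in one place: 4-fluoro-2-nitrophenyl in place of 2-bromophenyl on an oxygen on a saturated carbon. Compound 1 also carries a nitro group on its phenyl ring, and its step to compound 3 stayed within the scatter, while the step from compound 2 to compound 3 was modest. Compound 4 is therefore expected to give a number near that of compound 3, a 1.2-fold lower number from compound 3 to compound 4 (0.06 log units; within the scatter), with no step beyond the scatter. The estimate for compound 4 is 25 nM, within 10 nM to 70 nM.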

Compound 4, half-maximal inhibitory concentration: 20 nM
Estimate against measurement, compound 4: 1.3-fold (0.10 log units) above, and the stated range covers the measured number.
By their numbers in this assay, from the lowest: compounds 4, 1 and 3 (each within the scatter of the next); then compound 2.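

In this assay, 4-fluoro-2-nitrophenyl in place of 2-bromophenyl stays within the scatter (a 1.5-fold lower number from compound 3 to compound 4 (0.16 log units; within the scatter)), and so does fluoro in place of methylsulfanyl on an aromatic carbon (a 1.1-fold lower number from compound 1 to compound 4 (0.04 log units; within the scatter)). Only 4-(tert-butyl)phenyl stands apart (a 14-fold lower number from compound 2 to compound 4 (1.15 log units; beyond the scatter)), so compounds 1, 3 and 4 cannot be told apart despite their different substituted phenyl groups. Nothing available offers an explanation for this. From the compounds shown here alone, what an amine or a carboxylic acid would give in place of the nitro group stays open, as does whether an unsubstituted phenyl would match compound 3 or compound 2.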